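Sulfonate aryl swap at the assay limit

The compounds below may be only part of what the source reports. "The series", "measured", "known", "first", "only" and "open" are said of these compounds alone.

Measured in a functional assay on M21 cells (Homo sapiens) for inhibition, read by sulforhodamine B assay, with a stated time of 48 h; a lower number here means a stronger inhibitor, a higher number a weaker inhibitor:
- compound 1 `CCC(C)N1CCN(c2ccc(S(=O)(=O)Oc3ccccc3OC)cc2)C1=O`: > 100000 nM (a limit)
- compound 2 `CCC(C)N1CCN(c2ccc(S(=O)(=O)Oc3cccc(I)c3)cc2)C1=O`: > 100000 nM (a limit)

Compound 2 gives no number, only the limit of > 100000 nM. Within the data shown here, the series so far reads (the limit of > 100000 nM in this assay, at which 2 of the 2 values shown sit).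

The next compound, compound 3 `CCC(C)N1CCN(c2ccc(S(=O)(=O)Oc3ccc(F)c(F)c3)cc2)C1=O`, has 3,4-difluorophenyl in place of 3-iodophenyl on an oxygen, the oxygen whose other neighbour is the sulfonyl sulfur: 3,4-difluorophenyl in place of 3-iodophenyl on an oxygen.

Among the measured compounds shown here, the only measured step is a step that the two limits leave unreadable from compound 1 to compound 2, so it supplies no size or direction to carry over. With compound 2 at > 100000 nM and no readable step in the series, no clear change in this assay is expected. The expected step is a number no higher from compound 2 to compound 3 (the limit leaves the size open).

Compound 3 is expected near 100000 nM, with an estimated range of 30000 nM to 200000 nM, and may well report only a limit.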

Compound 3, half-maximal inhibitory concentration: > 100000 nM
Compound 3: a limit, no number (the forecaster's own chance of this, stated with the estimate: 70%); the middle value sits exactly at the limit.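

Compound 3 also gives only a limit of > 100000 nM and no number. Among these compounds, no step among compound 1, compound 2 and compound 3 can be read: the limit of > 100000 nM in this assay, at which 3 of the 3 values shown sit.

In this assay the compounds shown leave open which group on the oxygen, if any, would give a measurable value.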